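This account rests on a few compounds, and the source may have more. Where it says the series, first, only, none or still open, it means among the compounds named here.

Of the compounds shown here, three sharing one core have been measured in a functional assay on HL-60 cells (Homo sapiens) for inhibition; a higher number here means a weaker inhibitor, a lower number a stronger inhibitor. Compound 1 `OC[C@H]1OC(n2cnc3c(-c4cc[nH]n4)ncnc32)[C@H](O)[C@@H]1O` bears 1H-pyrazol-3-yl and gives 1170 nM. Compound 2 `OC[C@H]1OC(n2cnc3c(-c4ccccn4)ncnc32)[C@H](O)[C@@H]1O` bears pyridin-2-yl and gives 5600 nM. Compound 3 `OC[C@H]1OC(n2cnc3c(-c4ccsc4)ncnc32)[C@H](O)[C@@H]1O` bears thiophen-3-yl and gives 3800 nM.

Compound 3 stands second highest of the three numbers. Its nearest neighbour is compound 2, and the change a 1.5-fold lower number from compound 2 to compound 3 (0.17 log units; within the scatter) lies within the scatter, so the two cannot be ordered. Its furthest neighbour is compound 1, and the change a 3.2-fold higher number from compound 1 to compound 3 (0.51 log units; beyond the scatter) lies beyond the scatter.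

Compound 4 `OC[C@H]1OC(n2cnc3c(-c4ccc(O)cc4)ncnc32)[C@H](O)[C@@H]1O` differs from compound 3 at the same position that varies across the measured set: 4-hydroxyphenyl in place of thiophen-3-yl on an aromatic carbon. Going by the values given here, no measured step involves 4-hydroxyphenyl. Among the compounds with values here, what bears on the change is that every step at this position so far has been modest or within scatter: a 4.8-fold higher number from compound 1 to compound 2 (0.68 log units; beyond the scatter) and a 3.2-fold higher number from compound 1 to compound 3 (0.51 log units; beyond the scatter) were the larger ones, a 1.5-fold lower number from compound 2 to compound 3 (0.17 log units; within the scatter) the smallest. The swap from a five-membered ring with one hetero atom to a six-membered ring of carbon only, carrying a hydroxyl, is therefore expected to move the number by at most a modest amount, and the direction is uncertain, leaning slightly lower. Compound 4 is thus estimated to show a 1.5-fold lower number from compound 3 to compound 4 (0.18 log units; within the scatter) in this assay, giving an expected value of 2500 nM with a range from 900 nM to 7000 nM.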

Compound 4, half-maximal inhibitory concentration: 7600 nM
Estimate against measurement, compound 4: 3.0-fold (0.48 log units) below; the measured number lies above the stated range.
By their numbers in this assay, from the lowest: compound 1; then compounds 3, 2 and 4 (each within the scatter of the next).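

In this assay the changes a 2.0-fold higher number from compound 3 to compound 4 (0.30 log units; within the scatter) and a 1.4-fold higher number from compound 2 to compound 4 (0.13 log units; within the scatter) both lie within the scatter, so 4-hydroxyphenyl, a six-membered aromatic ring of carbon only that carries a hydroxyl, cannot be ordered against thiophen-3-yl or pyridin-2-yl. The change a 6.5-fold higher number from compound 1 to compound 4 (0.81 log units; beyond the scatter) is the largest seen so far at this position and lies beyond the scatter, which leaves compound 1, with its 1H-pyrazol-3-yl, as the strongest inhibitor of the four, while compounds 2, 3 and 4 form a single cluster despite their different rings. Nothing available here accounts for why compound 1 stands apart from the other three.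

The compounds shown leave open how much the hydroxyl itself contributes, since a plain phenyl at this position would be needed to separate it from the ring that carries it. They also leave open whether an amine or a carboxylic acid on such a ring, or a second pyrazole carrying a methyl group, would stay with compound 1 or fall into the cluster of the other three.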